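Shortening the octyl chain of compound 3 to ethyl

The compounds below may be only part of what the source reports. "The series", "measured", "known", "first", "only" and "open" are said of these compounds alone.

Of the compounds shown here, three have been read so far in a functional assay on HeLa cells (Homo sapiens) for cytotoxicity, read by WST assay, with a stated time of 48 h; a higher number here means a weaker inhibitor, a lower number a stronger inhibitor. Compound 1 (`COc1cc(C(c2ccc(O)c(OC)c2)[C@H](C)[C@H](C)CO)ccc1O`) gives > 100000 nM, which is a limit of the assay and not a number. Compound 2 (`COC[C@@H](C(C)C)C(c1ccc(O)c(OC)c1)c1ccc(O)c(OC)c1`) gives 69000 nM as a measured number. Compound 3 (`CCCCCCCC[C@H](C(C)C)C(c1ccc(O)c(OC)c1)c1ccc(O)c(OC)c1`), which carries octyl, gives 3100 nM and so holds the lower of the two numbers, with compound 2 higher by a margin beyond the scatter.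

Compound 4 (`CC[C@H](C(C)C)C(c1ccc(O)c(OC)c1)c1ccc(O)c(OC)c1`) turns octyl into ethyl, which is hydrogen in place of hexyl on a saturated chain carbon, four bonds along the chain from two aromatic carbons.

Within the data shown here, the only measured step is an at least 1.4-fold lower number from compound 1 to compound 2 (0.16 log units; that floor lies within the scatter). Among the measured compounds shown here, its floor lies within the scatter and it concerns a different group, so no measured step isolates this change. The nearest guide is compound 2, which has no octyl and stands at 69000 nM. A move to a higher number, a weaker inhibitor and beyond the scatter, is therefore expected in this assay. The expected size is a 13-fold higher number from compound 3 to compound 4 (1.11 log units; beyond the scatter). For compound 4 the estimated value is 40000 nM, with an expected range of 13000 nM to 100000 nM.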

Compound 4, half-maximal inhibitory concentration: 9700 nM
Compound 4: middle estimate off by 4.1-fold (0.62 log units), on the high side; measured number below the stated range.
By their numbers in this assay, from the lowest: compound 3; then compound 4; then compound 2. At a limit, above all of these: compound 1.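

Hydrogen in place of hexyl, four bonds along the chain from two aromatic carbons, gives a 3.1-fold higher number from compound 3 to compound 4 (0.50 log units; beyond the scatter) in this assay, the first step in the series that isolates this chain length; it is modest, and the short ethyl of compound 4 still keeps a measured number. On the saturated chain carbon bound to two aromatic carbons, 1-isopropylpropyl in place of 1-(methoxymethyl)-2-methylpropyl gives a 7.1-fold lower number from compound 2 to compound 4 (0.85 log units; beyond the scatter), so of the groups compared here, the plain hydrocarbon side chain of compound 4 gives the lower number, while octyl in compound 3 lowers it further. Compound 1 remains a limit and not a number, so 1-isopropylpropyl in place of 2-(hydroxymethyl)-1-methylpropyl yields only a floor, an at least 10-fold lower number from compound 1 to compound 4 (1.01 log units; beyond the scatter), and that step rests on a limit: the limit of > 100000 nM in this assay, at which 1 of the 4 values shown sits.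

From the compounds shown here alone, whether butyl or hexyl in this place would fall on a smooth line from ethyl to octyl, and whether a longer chain such as dodecyl would lower the number further, stays open. Also open, going by these compounds, is how a terminal amine or carboxylic acid on the chain would read in this assay.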